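This account rests on a few compounds, and the source may have more. Where it says the series, first, only, none or still open, it means among the compounds named here.

Compound 1 `O=C(CCCc1ccccc1)Nc1nc2ccccc2c(=O)s1` was examined in an assay on CHO cells for displacement of a labelled ligand from adenosine receptor A2b (Homo sapiens), read by scintillation counting, with a stated time of 75 min; on this read-out lower numbers stand for stronger inhibition and higher numbers for weaker inhibition. In this assay compound 1 gives > 1000 nM, which is a limit of the assay and not a measured number. Compound 2 `CN(C(=O)CCCc1ccccc1)c1nc2ccccc2c(=O)s1` differs from compound 1 by a methyl in place of hydrogen on an amide-type nitrogen. In this assay compound 2 gives > 1000 nM, again a limit of the assay. The step that the two limits leave unreadable from compound 1 to compound 2 therefore cannot be read, because both values sit at the limit of > 1000 nM in this assay, at which 2 of the 2 values shown sit. Compound 1 thus stands only at a limit, with no number to place it more exactly.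

Compound 3 `O=C(CCCc1ccccc1)Nc1nc2cc(Cl)ccc2c(=O)s1` differs from compound 1 by chloro in place of hydrogen on an aromatic carbon. Among the measured compounds shown here, no measured step bears directly on this change, and the single step that exists, from compound 1 to compound 2, is itself unreadable. With both measured compounds resting at the limit, nothing shown points to a change that would carry compound 3 away from it. Compound 3 is therefore expected to give about 2500 nM in this assay, within the range 500 nM to 15000 nM, the expected step being a step that the limit leaves unreadable from compound 1 to compound 3.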

Compound 3, inhibition constant: > 1000 nM
Compound 3: no number, only a limit; the forecaster's own chance of this, stated with the estimate: 75%; the middle value does not contradict the limit.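

The step from compound 1 to compound 3, chloro in place of hydrogen on an aromatic carbon, cannot be read, because both values are limits of the assay and not numbers: the limit of > 1000 nM in this assay, at which 3 of the 3 values shown sit.

The compounds shown leave open how far any of the three lies from that limit in this assay, and whether either change shifts the value at all.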